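Working notes: hydroxy in place of amino in compound 3

The compounds below may be only part of what the source reports. "The series", "measured", "known", "first", "only" and "open" are said of these compounds alone.

Values in a functional assay on NCI-H460 cells (Homo sapiens) for cytotoxicity, read by sulforhodamine B assay, with a stated time of 72 h (a lower number here means a stronger inhibitor, a higher number a weaker inhibitor), so far:
- compound 1 `COc1ccc(/C=C(/F)c2cc(OC)c(OC)c(OC)c2)cc1N` gives 2.4 nM
- compound 2 `COc1ccc(/C(F)=C\c2cc(OC)c(OC)c(OC)c2)cc1O` gives 4 nM
- compound 3 `COc1ccc(/C(F)=C(/F)c2cc(OC)c(OC)c(OC)c2)cc1N` gives 7.3 nM

Compound 3 lies within the scatter of compound 2 and beyond the scatter of compound 1, whose number is lower. Compound 4 `COc1ccc(/C(F)=C(/F)c2cc(OC)c(OC)c(OC)c2)cc1O` has hydroxy in place of amino on an aromatic carbon of compound 3 (hydroxy in place of amino on an aromatic carbon). Within the data shown here, no measured pair shows this exchange alone. In this assay compound 1, with amino, gives 2.4 nM and compound 2, with hydroxy, gives 4 nM within the scatter of each other, though the two differ elsewhere as well. The expected step is small and within the scatter (a 1.2-fold higher number from compound 3 to compound 4 (0.09 log units; within the scatter)). For compound 4 the estimated value is 9 nM (expected range 3 nM to 27 nM).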

Compound 4, half-maximal inhibitory concentration: 3 nM
Beside the measured number, compound 4's estimate is 3.0-fold (0.48 log units) above it; low and high end bracket the measured number.
By their numbers in this assay, from the lowest: compounds 1, 4, 2 and 3 (each within the scatter of the next, the first and the last beyond it).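

Hydroxy in place of amino, on the aromatic carbon ortho to a methoxy group, gives a 2.4-fold lower number from compound 3 to compound 4 (0.39 log units; beyond the scatter) in this assay, the first reading of this exchange alone. The position therefore responds modestly to the exchange, although both groups carry the same hydrogen-bond donor and acceptor counts. No available evidence bears on the origin of this step.

As far as these compounds go, whether the step keeps its size on the core of compound 1 or compound 2 remains open. From the compounds shown here alone, how a methylamino or acetamide group would read at this position also remains open.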